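Working notes: the step from compound 3 to compound 4

The compounds below may be only part of what the source reports. "The series", "measured", "known", "first", "only" and "open" are said of these compounds alone.

Measured compounds:
- Compound 1, `O=c1cc(Cn2cc(CCO)nn2)c2ccc(O)cc2o1`; in a functional assay on CFPAC-1 cells (Homo sapiens) for inhibition, read by MTT assay, with a stated time of 72 h (on this read-out higher numbers stand for weaker inhibition and lower numbers for stronger inhibition), compound 1 gives a limit, > 100000 nM.
- Compound 2, `O=c1cc(Cn2cc(CCCCO)nn2)c2ccc(O)cc2o1`; in this assay compound 2 gives a limit, > 100000 nM.
- Compound 3, `O=c1cc(Cn2cc(CSC(=S)N3CCOCC3)nn2)c2ccc(O)cc2o1`; in this assay compound 3 gives 56300 nM.

Among the compounds with values here, compound 3 holds the only actual number; the other two values sit at the limit of > 100000 nM in this assay, at which 2 of the 3 values shown sit. The steps into compound 3 are an at least 1.7-fold lower number from compound 1 to compound 3 (0.24 log units; that floor lies within the scatter) and an at least 1.7-fold lower number from compound 2 to compound 3 (0.24 log units; that floor lies within the scatter), both floored by limits. The step that the two limits leave unreadable from compound 1 to compound 2 is unreadable.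

Compound 4, `O=c1cc(Cn2cc(CSC(=S)N3CCNCC3)nn2)c2ccc(O)cc2o1`, differs from compound 3 by piperazin-1-yl in place of morpholin-4-yl on a thiocarbonyl carbon. Within the data shown here, no measured step touches the group on the thiocarbonyl carbon: the two readable steps swap the whole side chain on the saturated chain carbon, and the third is between limits. Nothing in the shown data therefore points to a step beyond the scatter in this assay in either direction.

Compound 4 is thus expected near compound 3, at an estimated 56000 nM, range 20000 nM to 150000 nM, which means an expected step of a 1.0-fold lower number from compound 3 to compound 4 (0.00 log units; within the scatter).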

Compound 4, half-maximal inhibitory concentration: > 100000 nM
Compound 4: only a limit was reported; the forecaster's own chance of this, stated with the estimate: 30%; at least 1.7-fold (0.25 log units) between middle value and limit.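

In this assay compound 4 gives > 100000 nM, which is a limit and not a number. Piperazin-1-yl in place of morpholin-4-yl on the thiocarbonyl carbon gives an at least 1.7-fold higher number from compound 3 to compound 4 (0.24 log units; that floor lies within the scatter), the only readable step so far that changes this group alone; its true size stays unknown, and its floor does not clear the scatter. The steps into compound 4 from compound 1 and compound 2 cannot be read, and the limit now covers most of the series: the limit of > 100000 nM in this assay, at which 3 of the 4 values shown sit.

As far as these compounds go, whether this position can give a clearly lower number in this assay remains open. Also open, from the compounds shown here alone, is how a piperidine ring or an open-chain diethylamino group on the thiocarbonyl carbon would read against compound 3.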